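This account rests on a few compounds, and the source may have more. Where it says the series, first, only, none or still open, it means among the compounds named here.

Working notes on the series. Of the compounds shown here, two have numbers so far in a functional assay on HeLa cells (Homo sapiens) for inhibition, read by MTT assay, with a stated time of 72 h; on this read-out lower numbers stand for stronger inhibition and higher numbers for weaker inhibition. Compound 1 `CCCCCCc1ccc(-c2cn(Cc3cc(=O)oc4cc(O)ccc34)nn2)cc1` gives 8730 nM, while compound 2 `Cn1c(-c2cn(Cc3cc(=O)oc4cc(O)ccc34)nn2)nc2ccccc21` gives 49200 nM, the highest of the two numbers shown; its nearest neighbour is compound 1, whose number is lower by a margin beyond the scatter. For the measured compounds named here, the two differ in more than one place, so no single structural step separates them. Compound 3 `Cc1ccc2c(Cn3cc(-c4nc5ccccc5n4C)nn3)cc(=O)oc2c1` carries the core of compound 2 with one change: methyl in place of hydroxy on an aromatic carbon. Going by the values given here, no measured pair shows this kind of swap, so there is no step on which to rest an expectation of direction. The number for compound 3 is therefore expected near that of compound 2, with the step from compound 2 to compound 3 estimated as a 1.1-fold higher number from compound 2 to compound 3 (0.05 log units; within the scatter), no larger than the scatter in either direction. In this assay compound 3 is estimated at 55000 nM, within a range from 18000 nM to 160000 nM.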

Compound 3, half-maximal inhibitory concentration: 17500 nM
Estimate against measurement, compound 3: 3.1-fold (0.50 log units) above, outside the stated range (below it).
By their numbers in this assay, from the lowest: compounds 1 and 3 (each within the scatter of the next); then compound 2.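

In this assay, for the compounds shown here, methyl in place of hydroxy on an aromatic carbon gives a 2.8-fold lower number from compound 2 to compound 3 (0.45 log units; beyond the scatter), the first step that can be read at a single place. On this one pair, the hydroxy is not needed to hold the number where it stands: when it leaves, the number falls beyond the scatter rather than rising. Nothing measured on these compounds accounts for the size or direction of this step.

On these data alone, whether the same swap gives a step of like direction on the core of compound 1 remains open. Also open, as far as these compounds go, is how a methoxy, an amine or a chlorine at this place would compare with the methyl of compound 3.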